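Ethyl to tert-butyl on the ester: growth inhibition notes

The compounds below may be only part of what the source reports. "The series", "measured", "known", "first", "only" and "open" are said of these compounds alone.

Measured in a functional assay on A549 cells (Homo sapiens) for inhibition, read by MTT assay, with a stated time of 72 h; a lower number here means a stronger inhibitor of growth, a higher number a weaker inhibitor of growth:
compound 1 `COC(=O)/C=C/C1=CC[C@H]2C(C)(C)CCC[C@]2(C)[C@H]1C=O` gives 21000 nM as its value
compound 2 `CCOC(=O)/C=C/C1=CC[C@H]2C(C)(C)CCC[C@]2(C)[C@H]1C=O` gives 25000 nM as its value
compound 3 `CCOC(=O)/C(C)=C/C1=CC[C@H]2C(C)(C)CCC[C@]2(C)[C@H]1C=O` gives 26000 nM as its value

Compound 2 at 25000 nM lies within the scatter of compound 1 and of compound 3, so the three values form one level. Compound 4 `CC(C)(C)OC(=O)/C=C/C1=CC[C@H]2C(C)(C)CCC[C@]2(C)[C@H]1C=O` carries tert-butyl in place of ethyl on an oxygen next to a carbonyl group. Going by the values given here, the only measured step on this group is a 1.2-fold higher number from compound 1 to compound 2 (0.08 log units; within the scatter) and it stays within the scatter. Tert-butyl itself has no measured precedent, so the range is kept wide, and no step beyond the scatter is expected in this assay here. The estimated change is a 1.1-fold higher number from compound 2 to compound 4 (0.03 log units; within the scatter) and lies within the scatter. For compound 4 the estimated value is 27000 nM with an expected range from 14000 nM to 50000 nM in this series.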

Compound 4, concentration for 50% growth inhibition: 29000 nM
Compound 4: middle estimate off by 1.1-fold (0.03 log units), on the low side; the measured number falls inside the stated range.
By their numbers in this assay, from the lowest: compounds 1, 2, 3 and 4 (each within the scatter of the next).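

Going by these compounds alone, on the oxygen next to a carbonyl group, tert-butyl now joins methyl and ethyl: this assay shows a 1.2-fold higher number from compound 2 to compound 4 (0.06 log units; within the scatter) and a 1.4-fold higher number from compound 1 to compound 4 (0.14 log units; within the scatter), so the first branched group at this place stays on the same level as the two unbranched ones. Nothing measured here gives a reason for this flat result.

Still open, from the compounds shown here alone, is whether a longer chain ending in an amine on this oxygen, or the free carboxylic acid in place of the ester, would leave this level.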